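Replacing the Terminal Phenyl with a Pentyl Chain

The compounds below may be only part of what the source reports. "The series", "measured", "known", "first", "only" and "open" are said of these compounds alone.

Measured compounds:
Compound 1 `C=C(C)C#Cc1ccc(CCC(=O)O)c(F)c1` gives 81.3 nM in a functional assay on 1321-N1 cells for agonist activity at Free fatty acid receptor 1 (Homo sapiens), read by calcium flux, with a stated time of 0.4 s; a higher number here means that more compound is needed for the effect, a lower number that less compound is needed.
Compound 2 `O=C(O)CCc1ccc(C#CCc2ccccc2)cc1` gives 389 nM in this assay.
Compound 3 `O=C(O)CCc1ccc(C#CCCc2ccccc2)cc1` gives 1820 nM in this assay.

Compound 3 stands highest of the three numbers; compound 2 lies nearest, with a lower number, and compound 1 furthest, with a still lower number. Compound 4 `CCCCCCCC#Cc1ccc(CCC(=O)O)cc1` has not yet been measured. It differs from compound 3 by pentyl in place of phenyl on a saturated chain carbon, two bonds along the chain from a triple-bonded carbon. Among the measured compounds shown here, only one measured step bears on this neighbourhood: a 4.7-fold higher number from compound 2 to compound 3 (0.67 log units; beyond the scatter), where lengthening the saturated chain toward the aromatic ring raised the number. For the measured compounds named here, no measured pair shows a ring giving way to an open chain, so the direction of the present change rests on no direct precedent. Given the already high number of compound 3, and with no shown step that exchanges an aromatic ring for an alkyl chain, the step of a 1.4-fold higher number from compound 3 to compound 4 (0.14 log units; within the scatter) is expected to stay small, with the wide uncertainty that such an untested exchange carries. Compound 4 is therefore estimated at 2500 nM, within a range of 700 nM to 9000 nM.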

Compound 4, half-maximal effective concentration: 1450 nM
Estimate against measurement, compound 4: 1.7-fold (0.24 log units) above, within the range that was stated.
By their numbers in this assay, from the lowest: compound 1; then compound 2; then compounds 4 and 3 (each within the scatter of the next).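

In this assay, an open pentyl chain in place of the phenyl at this position gives a 1.3-fold lower number from compound 3 to compound 4 (0.10 log units; within the scatter) and so leaves the two compounds within the scatter of each other; the aromatic ring at the end of this longer chain is thus not needed to hold the number at this level. Measured from compound 2, hexyl in place of phenyl gives a 3.7-fold higher number from compound 2 to compound 4 (0.57 log units; beyond the scatter) and thus stands beyond the scatter, as does a 4.7-fold higher number from compound 2 to compound 3 (0.67 log units; beyond the scatter) with the benzyl group. No supporting evidence accounts for these numbers.

As far as these compounds go, it remains open whether a shorter open chain, such as propyl or butyl, would bring the number back toward that of compound 2. From the compounds shown here alone, it is equally open whether a saturated cyclohexyl ring would behave like the phenyl or like the pentyl chain.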